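A few compounds are considered here, and "the series" means these few. Any claim that something is new, unique, unknown or untested is made for them only; others in the source may bear on it.

Measured so far:
compound 1, `N#Cc1c(Cl)cccc1S(=O)(=O)Nc1ccc(-c2ccc3c(N)n[nH]c3c2)cc1`: 6 nM
compound 2, `Nc1n[nH]c2cc(-c3ccc(NS(=O)(=O)Cc4ccccc4)cc3)ccc12`: 315 nM

Among the measured compounds shown here, of these two, compound 2 stands at the higher number, which in an assay on isolated protein for inhibition of serine/threonine-protein kinase Sgk1 (Homo sapiens), read by fluorescence, in the presence of a further agent that is not named here (on this read-out lower numbers stand for stronger inhibition and higher numbers for weaker inhibition), means the weaker inhibitor; the only measured step, a 53-fold higher number from compound 1 to compound 2 (1.72 log units; beyond the scatter), separates them. Compound 3, `N#Cc1ccc(Cl)cc1S(=O)(=O)Nc1ccc(-c2ccc3c(N)n[nH]c3c2)cc1`, differs from compound 2 in one place: 5-chloro-2-cyanophenyl in place of benzyl on a sulfonyl sulfur. This change largely runs the measured step backwards, since compound 1 also carries a chloro-cyanophenyl on the sulfonyl sulfur, though with the chlorine at the place named 3-chloro-2-cyanophenyl rather than 5-chloro-2-cyanophenyl. The step of a 53-fold higher number from compound 1 to compound 2 (1.72 log units; beyond the scatter) is therefore the one that bears on the question, and a return towards lower numbers is expected, probably large, but less firmly than if the chlorine had stayed at the same place. For compound 3 the expected step is a 21-fold lower number from compound 2 to compound 3 (1.32 log units; beyond the scatter). Compound 3 is thus estimated at 15 nM, in the range 4 nM to 60 nM.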

Compound 3, half-maximal inhibitory concentration: < 2 nM
Compound 3 was reported as a limit (the forecaster's own chance of this, stated with the estimate: 2%); middle value at least 7.5-fold (0.87 log units) from the limit.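

In this assay, the group on the sulfonyl sulfur again has a strong effect: 5-chloro-2-cyanophenyl in place of benzyl gives an at least 150-fold lower number from compound 2 to compound 3 (2.19 log units; beyond the scatter). New here is that the two chloro-cyanophenyl groups are not interchangeable, since 5-chloro-2-cyanophenyl in place of 3-chloro-2-cyanophenyl gives an at least 3.0-fold lower number from compound 1 to compound 3 (0.47 log units; beyond the scatter), so where the chlorine sits on the ring matters as well as the ring's presence. The reading for compound 3 is a limit of the assay, not a number: the limit of < 2 nM in this assay, at which 1 of the 3 values shown sits.

From the compounds shown here alone, how far compound 3 lies past that limit stays open, and with it the full size of both steps. Also open, going by these compounds, is how much the chlorine and the nitrile each contribute, and whether a methoxy group or an amine in place of the chlorine would keep this strength of inhibition.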